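A longer iodoacetamide arm on the shared core

The source may report more compounds than this note shows. Statements on the series, on what has been measured and on what is new or still open speak of the compounds shown alone.

Measured compounds:
compound 1, `O=C(CI)NCCCCCCCNc1ncnc2c1ncn2[C@@H]1O[C@H](COP(=O)(O)OP(=O)(O)OP(=O)(O)O)[C@@H](O)[C@H]1O`, 20%
compound 2, `Nc1ncnc2c1nc(NCCCCCCNC(=O)CI)n2[C@@H]1O[C@H](COP(=O)(O)OP(=O)(O)OP(=O)(O)O)[C@@H](O)[C@H]1O`, 0%
compound 3, `CN(CCCN(C)C(=O)CCCNc1ncnc2c1ncn2[C@@H]1O[C@H](COP(=O)(O)OP(=O)(O)OP(=O)(O)O)[C@@H](O)[C@H]1O)C(=O)CCCNC(=O)CI`, 0%

In an assay on isolated protein for inhibition of hexokinase-3 (Rattus norvegicus), with a stated time of 6 h, tested at 10 mM (on this read-out lower numbers stand for less inhibition and higher numbers for more inhibition at the one concentration tested (going by the name of the read-out)), compound 1 gives 20%, the highest of the three numbers. Compound 2 gives 0% and compound 3 gives 0%, both beyond the scatter below compound 1. Compound 4, `O=C(I)NCC(=O)NCCCCCCNc1ncnc2c1ncn2[C@@H]1O[C@H](COP(=O)(O)OP(=O)(O)OP(=O)(O)O)[C@@H](O)[C@H]1O`, differs from compound 1 in one place: a group of 8 heavy atoms (3 carbon, 2 nitrogen, 2 oxygen, 1 iodine; no ring) in place of a group of 6 heavy atoms (3 carbon, 1 nitrogen, 1 oxygen, 1 iodine; no ring), on a saturated chain carbon, six bonds along the chain from a nitrogen on an aromatic ring. For the measured compounds named here, no pair of measured compounds differing in one place exists, so the size of this step cannot be read from the data. A modest downward step is expected, since compound 2 with its iodoacetamide arm elsewhere gives 0%. The step from compound 1 to compound 4 in this assay is estimated at a number 10 percentage points lower from compound 1 to compound 4 (within the scatter). Compound 4 is thus expected to give 10%, within a range from 0% to 30%.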

Compound 4, a percentage reported as inhibition, at one concentration (the size of the read-out at that concentration, not a potency): 0%
Compound 4: the middle estimate sits 10 percentage points above what was measured; low and high end bracket the measured number.
By their numbers in this assay, from the lowest: compounds 2, 3 and 4 (each within the scatter of the next); then compound 1.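

For the compounds shown here, at the saturated chain carbon, six bonds along the chain from a nitrogen on an aromatic ring, this change gives the only step that can be read in this assay: a number 20 percentage points lower from compound 1 to compound 4 (beyond the scatter). Putting the group of 8 heavy atoms, with its added hydrogen-bond donor and acceptor, in place of (((iodomethyl)carbonyl)amino)methyl leaves compound 4 at 0%. Nothing measured here explains this drop. From the compounds shown here alone, whether a shorter chain ending in the same iodoacetamide would keep the inhibition seen with compound 1 stays open, as does the effect of an amine or a carboxylic acid at this place.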